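Turning One Stereocentre: Will Lipophilicity Shift?

This account rests on a few compounds, and the source may have more. Where it says the series, first, only, none or still open, it means among the compounds named here.

Among the measured compounds shown here, in a physicochemical assay for lipophilicity, measured as octanol-water partition, at pH 7.4 (on this read-out lower numbers stand for lower lipophilicity and higher numbers for higher lipophilicity), compound 1 `Cc1ccc2[nH]c(C(=O)N[C@H]3CN(S(=O)(=O)c4ccccc4)C[C@@H]3C(=O)NCCN(C)C)cc2c1` gives 2.1 and its mirror image compound 2 `Cc1ccc2[nH]c(C(=O)N[C@@H]3CN(S(=O)(=O)c4ccccc4)C[C@H]3C(=O)NCCN(C)C)cc2c1` stands level with it at 2.1 on the numbers so far. For the measured compounds named here, because of the fact that compounds 1 and 2 differ only in the configuration as drawn the only measured step is no change at the digits printed from compound 1 to compound 2 (within the scatter) and it inverts every stereocentre at once. For compound 3 `Cc1ccc2[nH]c(C(=O)N[C@H]3CN(S(=O)(=O)c4ccccc4)C[C@H]3C(=O)NCCN(C)C)cc2c1` the change is this: the two compounds have the same atoms and bonds and differ only in configuration as drawn: 1 of 2 stereo elements differ; a stereocentre at a saturated ring carbon is drawn S in compound 2 and R in compound 3 and so compound 3 is no mirror image of compound 2, which leaves that measured step only a weak guide. No step beyond the scatter is expected, so no change at the digits printed from compound 2 to compound 3 (within the scatter) is the estimate in this assay for now. The expected value for compound 3 is 2.1 with an estimated range from 1.7 to 2.5 in this measurement.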

Compound 3, distribution coefficient: 2.3
Beside the measured number, compound 3's estimate is 0.20 log units below it; the measured number falls inside the stated range.
By their numbers in this assay, from the lowest: compounds 1, 2 and 3 (each within the scatter of the next).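

Turning a single stereocentre at a saturated ring carbon, rather than both at once, gives a number 0.20 log units higher from compound 2 to compound 3 (within the scatter) in this assay. Turning the other one gives a number 0.20 log units higher from compound 1 to compound 3 (within the scatter). So each centre has now been changed alone, which a mirror-image pair cannot show, and in this assay neither change lies beyond the scatter.

All three compounds carry the same groups, so these steps describe configuration only. On these data alone, whether they stay within the scatter with a carboxylic acid or a longer chain in place of the dimethylamino group remains open.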